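Amide variation on the anilide of compound 1

This account rests on a few compounds, and the source may have more. Where it says the series, first, only, none or still open, it means among the compounds named here.

Compound 1 `COc1cc(/C=C/C(=O)c2cccc(NC(=O)c3c(Cl)cccc3Cl)c2)ccc1O` carries a 2,6-dichlorophenyl on the amide carbonyl. In a functional assay on Vero cells (Chlorocebus sabaeus) for inhibition (on this read-out lower numbers stand for stronger inhibition and higher numbers for weaker inhibition), compound 1 gives 2.48 ug/mL, the lowest of the two numbers recorded in this series, with compound 2 `COc1cc(/C=C/C(=O)c2cccc(NC(=O)c3ccco3)c2)ccc1O` nearest at 3.11 ug/mL. Compound 3 `COc1cc(/C=C/C(=O)c2cccc(NC(=O)c3ccc(Cl)c(Cl)c3)c2)ccc1O` is reported only as a limit of this assay, > 50 ug/mL, as noted in the limit of > 50 ug/mL in this assay, at which 1 of the 3 values shown sits.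

Two measured steps start from compound 1. Exchanging the aryl amide for a heteroaryl amide gives a 1.3-fold higher number from compound 1 to compound 2 (0.10 log units; within the scatter). Moving the chlorines to the 3,4-pattern gives an at least 20-fold higher number from compound 1 to compound 3 (1.30 log units; beyond the scatter), and from the furanyl amide the same endpoint reads an at least 16-fold higher number from compound 2 to compound 3 (1.20 log units; beyond the scatter).

Compound 4 `CCCC(=O)Nc1cccc(C(=O)/C=C/c2ccc(O)c(OC)c2)c1` has not been measured in this assay. Relative to compound 1 the change is propyl in place of 2,6-dichlorophenyl on a carbonyl carbon. For the measured compounds named here, no measured step replaces the aryl amide by an alkyl amide, so the two steps from compound 1 give only the spread of what an amide change can do here: one within the scatter, one large and toward weaker inhibition. A moderate loss is therefore expected, as a 2.4-fold higher number from compound 1 to compound 4 (0.38 log units; beyond the scatter), while the possibility of a limit cannot be excluded. For compound 4 the estimate in this assay is 6 ug/mL, expected to lie between 1.5 ug/mL and 30 ug/mL.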

Compound 4, half-maximal inhibitory concentration: 2.04 ug/mL
Beside the measured number, compound 4's estimate is 2.9-fold (0.47 log units) above it, within the range that was stated.
By their numbers in this assay, from the lowest: compounds 4, 1 and 2 (each within the scatter of the next). At a limit, above all of these: compound 3.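

In this assay, the change to the propyl amide reads a 1.2-fold lower number from compound 1 to compound 4 (0.08 log units; within the scatter), and from the furanyl amide it reads a 1.5-fold lower number from compound 2 to compound 4 (0.18 log units; within the scatter), so a ring on this carbonyl carbon is not required for a number in the range of compound 1 and compound 2. Compounds 1, 2 and 4 now span a 2,6-dichlorophenyl, a furan-2-yl and a propyl with no step beyond the scatter among them, and compound 3 is the one exception, with the propyl amide reading an at least 24-fold lower number from compound 3 to compound 4 (1.38 log units; beyond the scatter). The value of compound 3 is a limit of the assay, not a number, so the size of that step has no upper bound here: the limit of > 50 ug/mL in this assay, at which 1 of the 4 values shown sits.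

Going by these compounds, what remains open is whether the tolerance at this position extends to a longer chain, a branched chain such as tert-butyl, or a chain ending in an amine or a carboxylic acid. An unsubstituted phenyl or a 4-chlorophenyl on the same carbonyl carbon would show whether the large step at compound 3 belongs to the 3,4-dichlorophenyl alone or to a wider set of aryl amides.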